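A few compounds are considered here, and "the series" means these few. Any claim that something is new, unique, unknown or untested is made for them only; others in the source may bear on it.

Measured so far in an ADME assay on HEK-293T cells (Homo sapiens) for cytotoxicity, read by CCK-8 assay, with a stated time of 48 h; on this read-out lower numbers stand for stronger inhibition and higher numbers for weaker inhibition: compound 1 `O=[N+]([O-])c1ccc(NC(=S)NCCNS(=O)(=O)c2ccc(-c3ccccc3O[C@H]3CC[C@@H](O)CC3)s2)cc1` gives 20000 nM. Compound 2 `Cc1cc(C)cc(NC(=O)NCCNS(=O)(=O)c2ccc(-c3ccccc3OCc3ccccc3)s2)c1` reaches only the limit of > 20000 nM. Compound 3 `O=[N+]([O-])c1cccc(NC(=S)NCCNS(=O)(=O)c2ccc(-c3ccccc3OCc3ccccc3)s2)c1` gives 18300 nM.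

Compound 3 stands nearest to compound 1, and the two numbers lie within the scatter of each other, while the third value is a limit. Compound 4 `O=[N+]([O-])c1ccc(NC(=S)NCCNS(=O)(=O)c2ccc(-c3ccccc3OCc3ccccc3)s2)cc1` differs from compound 3 by 4-nitrophenyl in place of 3-nitrophenyl on an amide-type nitrogen. Within the data shown here, only one measured step exists, an at least 1.0-fold lower number from compound 2 to compound 3 (0.03 log units; that floor lies within the scatter), and it starts from a limit (the limit of > 20000 nM in this assay, at which 1 of the 3 values shown sits), so it sets no size for any step. Compound 1 carries the same 4-nitrophenyl group on the thiourea and shows a number close to compound 3. For compound 4, no step beyond the scatter is therefore expected: a 1.1-fold higher number from compound 3 to compound 4 (0.04 log units; within the scatter). Compound 4 is estimated at 20000 nM, between 10000 nM and 40000 nM.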

Compound 4, half-maximal inhibitory concentration: 8900 nM
The estimate for compound 4 lay 2.2-fold (0.35 log units) above the measured number, and the stated range ends above it.
By their numbers in this assay, from the lowest: compound 4; then compounds 3 and 1 (each within the scatter of the next).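

On the amide-type nitrogen, the place of the nitro group matters: 4-nitrophenyl in place of 3-nitrophenyl gives a 2.1-fold lower number from compound 3 to compound 4 (0.31 log units; beyond the scatter) in this assay. The group on the oxygen counts too, since benzyl in place of 4-hydroxycyclohexyl gives a 2.2-fold lower number from compound 1 to compound 4 (0.35 log units; beyond the scatter). The step of an at least 2.2-fold lower number from compound 2 to compound 4 (0.35 log units; beyond the scatter) sets only a floor, because compound 2 stands at a limit: the limit of > 20000 nM in this assay, at which 1 of the 4 values shown sits.

Going by these compounds, whether an amine or a carboxylic acid in place of the nitro group would keep the lower number stays open. So does whether 3-nitrophenyl and 4-nitrophenyl differ in the same way with 4-hydroxycyclohexyl on the oxygen.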